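This account rests on a few compounds, and the source may have more. Where it says the series, first, only, none or still open, it means among the compounds named here.

In a functional assay on CAL-51 cells (Homo sapiens) for antiproliferative activity, read by luminescence and CellTiter-Glo, with a stated time of 3 days (on this read-out higher numbers stand for weaker inhibition and lower numbers for stronger inhibition), the series so far reads as follows:

- compound 1 `COc1cc(C(=O)N(C)C)ccc1Nc1nc(OC2CCCCC2)c2cc[nH]c2n1` gives 190 nM in this read-out
- compound 2 `COc1cc(N2CCN(C3COC3)CC2)ccc1Nc1nc(O[C@H]2CCOC(C)(C)C2)c2cc[nH]c2n1` gives 84 nM in this read-out

Compound 1 holds the higher of the two numbers, and compound 2 sits lower by more than the usual scatter of repeated measurements. The two differ in more than one place, so that gap cannot be tied to any single change.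

Compound 3 `COc1cc(C(=O)N(C)C)ccc1Nc1nc(O[C@H]2CC[C@@](C)(O)CC2)c2cc[nH]c2n1` departs from compound 1 in one place, on an oxygen on an aromatic ring, where the change reads 4-hydroxy-4-methylcyclohexyl in place of cyclohexyl on an oxygen on an aromatic ring and 4-hydroxy-4-methylcyclohexyl stands in place of cyclohexyl. Among the measured compounds shown here, no measured pair differs in one place, so the data offer no direct precedent for this change. In this assay a modest shift is expected, with a slight lean toward a higher number and no firm direction. The expected step of a 1.2-fold higher number from compound 1 to compound 3 (0.06 log units; within the scatter) stays within the scatter. For compound 3 the estimated value is 220 nM with an expected range from 60 nM to 750 nM once measured.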

Compound 3, half-maximal inhibitory concentration: 44 nM
For compound 3 the middle estimate is 5.0-fold (0.70 log units) above the measured one, and the stated range ends above it.
By their numbers in this assay, from the lowest: compounds 3 and 2 (each within the scatter of the next); then compound 1.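

In this assay, the cyclohexyl on an oxygen on an aromatic ring is not a fixed requirement: putting 4-hydroxy-4-methylcyclohexyl in its place gives a 4.3-fold lower number from compound 1 to compound 3 (0.64 log units; beyond the scatter). Among the compounds shown here, this is the first step that differs in one place, so it ties a change in the read-out to this position with the rest of compound 1 held constant, which the gap between compound 1 and compound 2 could not do. Nothing at hand gives a reason for the step.

On these data alone, whether the step belongs to the hydroxy group, the methyl group or both, and how far it depends on the two defined stereocentres as drawn, remains open, as does whether an amine or a carboxylic acid in place of that hydroxy group would read the same way. Also open, as far as these compounds go, is whether the same exchange keeps its size when the rest of the molecule differs, as it does in compound 2.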